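The source may hold more compounds than are shown below. What is called first, only, known or untested is meant among the compounds shown, and "the series" means these compounds.

Measured in a functional assay on HEK293 cells for positive allosteric modulation of metabotropic glutamate receptor 5 (Homo sapiens), read by FLIPR and calcium flux; a lower number here means that less compound is needed, a higher number that more compound is needed for the effect:
compound 1 `CC(C)NC(=O)c1ccc(C#Cc2ccccc2)nc1`: 62 nM
compound 2 `Cc1cccc(C#Cc2ccc3c(n2)CCN(C2CCCC2)C3=O)c1`: 7.5 nM
compound 3 `Cc1ccc(C#Cc2ccc3c(n2)CCN(C2CCCC2)C3=O)cc1`: 4820 nM

Compound 3 stands highest of the three numbers in this assay; compound 1 gives 62 nM, and compound 2 gives the lowest number, 7.5 nM. Among the measured compounds shown here, the only single-point step within the measured set is a 640-fold higher number from compound 2 to compound 3 (2.81 log units; beyond the scatter), a large move when 3-methylphenyl is swapped for 4-methylphenyl on the triple-bonded carbon.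

Compound 4 `O=C1c2ccc(C#Cc3cccc(Cl)c3)nc2CCN1C1CCCC1` is not yet measured. It differs from compound 3 by 3-chlorophenyl in place of 4-methylphenyl on a triple-bonded carbon. For the measured compounds named here, this change reverses the pattern of the one measured step: the substituent returns to the 3-position of the phenyl, though chlorine now stands where methyl stood in compound 2. Going by the values given here, no measured pair tests chlorine against methyl, so that part of the change is unknown. Because the step from compound 2 to compound 3 was a 640-fold higher number from compound 2 to compound 3 (2.81 log units; beyond the scatter), a large step back down in this assay is expected for compound 4, of about a 320-fold lower number from compound 3 to compound 4 (2.51 log units; beyond the scatter). The estimate for compound 4 in this assay is 15 nM, with a range from 4 nM to 80 nM.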

Compound 4, half-maximal effective concentration: 33 nM
For compound 4 the middle estimate is 2.2-fold (0.34 log units) below the measured one; low and high end bracket the measured number.
By their numbers in this assay, from the lowest: compound 2; then compounds 4 and 1 (each within the scatter of the next); then compound 3.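

Both 3-methylphenyl and 3-chlorophenyl give far lower numbers in this assay than 4-methylphenyl, so the high number of compound 3 does not carry over to either of these two groups on the triple-bonded carbon (a 150-fold lower number from compound 3 to compound 4 (2.16 log units; beyond the scatter)). Among the compounds shown here, the first direct comparison of chloro with methyl on the aromatic carbon gives a modest step that still lies beyond the scatter (a 4.4-fold higher number from compound 2 to compound 4 (0.64 log units; beyond the scatter)), far smaller than the step from 3-chlorophenyl to 4-methylphenyl, so the choice between these two phenyl groups matters much more here than the choice of chloro or methyl. Nothing available explains either step.

From the compounds shown here alone, whether the steep dependence on the phenyl group also holds for 4-chlorophenyl remains open, as this would separate the effect of chloro from that of the methyl group. Also open, going by these compounds, is how unsubstituted phenyl, or a methoxy or nitrile group on that ring, would compare with compound 2.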